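Chloro for trifluoromethyl on the benzoate ester

The compounds below may be only part of what the source reports. "The series", "measured", "known", "first", "only" and "open" are said of these compounds alone.

Compound 1 `CC1=CC[C@H](C(C)C)c2cc(C)c(OC(=O)c3ccc([N+](=O)[O-])cc3)cc21` gives 89% in a functional assay on K562 cells (Homo sapiens) for antiproliferative activity, read by sulforhodamine B assay, with a stated time of 48 h, tested at 50 uM; on this read-out higher numbers stand for more inhibition at the one concentration tested (going by the name of the read-out) and lower numbers for less inhibition.
Compound 2 `CC1=CC[C@H](C(C)C)c2cc(C)c(OC(=O)c3ccc(C(F)(F)F)cc3)cc21` gives 9% in this assay.

Among the measured compounds shown here, compound 2 stands lowest of the two numbers, with compound 1 as its only neighbour. For the measured compounds named here, the single measured step, a number 80 percentage points lower from compound 1 to compound 2 (beyond the scatter), shows that exchanging the group at this position can move the read-out by a large margin. Compound 3 `CC1=CC[C@H](C(C)C)c2cc(C)c(OC(=O)c3ccc(Cl)cc3)cc21` carries chloro in place of trifluoromethyl on an aromatic carbon. Going by the values given here, no measured step involves chloro, so the direction is open; the exchange could recover part of the activity of compound 1 or stay near compound 2. Compound 3 is therefore expected at 30%, within 5% to 70%, meaning an estimated a number 21 percentage points higher from compound 2 to compound 3 (beyond the scatter).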

Compound 3, a percentage reported as inhibition, at one concentration (the size of the read-out at that concentration, not a potency): 58.9%
For compound 3 the middle estimate is 28.9 percentage points below the measured one; the measured number falls inside the stated range.
By their numbers in this assay, from the lowest: compound 2; then compound 3; then compound 1.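

Chloro recovers much of the inhibition seen with nitro but absent with trifluoromethyl (a number 49.9 percentage points higher from compound 2 to compound 3 (beyond the scatter)), yet it does not fully match nitro (a number 30.1 percentage points lower from compound 1 to compound 3 (beyond the scatter)). Among the compounds shown here, the three groups at this position on the benzoate therefore give three separate levels, with nitro highest, chloro in the middle and trifluoromethyl lowest, so nitro is not the only group here that gives marked inhibition at the one concentration tested. No available evidence explains this order.

Where an amine, a carboxylic acid or a methoxy group would fall in this order remains open. From the compounds shown here alone, whether an amide could replace the ester linkage in these compounds also remains open.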